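The source may hold more compounds than are shown below. What is called first, only, known or untested is meant among the compounds shown, and "the series" means these compounds.

In a functional assay on HCT-15 cells (Homo sapiens) for cytotoxicity, in the presence of a further agent that is not named here (on this read-out higher numbers stand for weaker inhibition and lower numbers for stronger inhibition), three compounds sharing one core have been measured. Compound 1 `Clc1ccc(-c2cc(-c3ccc(Cl)o3)cc(-c3ccsc3)n2)cc1` gives 5190 nM. For compound 2 `Cc1ccc(-c2cc(-c3ccc(Cl)o3)cc(-c3ccsc3)n2)o1`, the assay reports only a limit, > 50000 nM. Compound 3 `Clc1cccc(-c2cc(-c3ccc(Cl)o3)cc(-c3cccs3)n2)c1` gives 15500 nM, the higher of the two true numbers, and compound 1 lies lower by more than the scatter.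

Compound 4 `Clc1cccc(-c2cc(-c3ccc(Cl)o3)cc(-c3ccsc3)n2)c1` has not yet been measured. It has the same atoms as compound 3, joined differently, with thiophen-3-yl in place of thiophen-2-yl on an aromatic carbon. Going by the values given here, no measured step tests this exchange directly. Among the compounds with values here, the only step available, an at least 9.6-fold higher number from compound 1 to compound 2 (0.98 log units; beyond the scatter), is beyond the scatter, but it replaces a different group altogether, so it offers little guidance on the size of this change. A weaker pointer is that compound 1 also carries thiophen-3-yl and gives 5190 nM. On that basis, a small shift towards a lower number is expected, probably not clearly beyond the scatter. The estimated change is a 1.6-fold lower number from compound 3 to compound 4 (0.19 log units; within the scatter). Compound 4 is expected to give about 10000 nM, with an estimated range from 4000 nM to 25000 nM.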

Compound 4, half-maximal inhibitory concentration: 13700 nM
Compound 4: the middle estimate sits 1.4-fold (0.14 log units) below what was measured; low and high end bracket the measured number.
By their numbers in this assay, from the lowest: compound 1; then compounds 4 and 3 (each within the scatter of the next). At a limit, above all of these: compound 2.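

The exchange of thiophen-2-yl for thiophen-3-yl, on the aromatic carbon next to the ring nitrogen, is now tested directly in this assay, and a 1.1-fold lower number from compound 3 to compound 4 (0.05 log units; within the scatter) shows that the two thiophene attachments cannot be told apart here. Going by these compounds alone, the chlorine on the phenyl group proves to matter more, since a 2.6-fold higher number from compound 1 to compound 4 (0.42 log units; beyond the scatter), with 3-chlorophenyl in place of 4-chlorophenyl and the thiophen-3-yl group held constant, is the first step that changes only this chlorine's place on the phenyl group. Compound 2 stands at a limit of the assay, so an at least 3.6-fold lower number from compound 2 to compound 4 (0.56 log units; beyond the scatter), with 3-chlorophenyl in place of 5-methylfuran-2-yl, gives a bound rather than a true size: the limit of > 50000 nM in this assay, at which 1 of the 4 values shown sits.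

The compounds shown leave open whether the gap between 3-chlorophenyl and 4-chlorophenyl persists when thiophen-2-yl is present, since only thiophen-3-yl backs that comparison. Every compound shown also carries a thiophene at this carbon, so what an amine or a carboxylic acid would do there remains unknown, as does any change to the 5-chlorofuran-2-yl group.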